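Tert-butyl on the benzamido group of compound 1

The source may hold more compounds than are shown below. What is called first, only, known or untested is meant among the compounds shown, and "the series" means these compounds.

In a functional assay on JeKo-1 cells (Homo sapiens) for antiproliferative activity (on this read-out lower numbers stand for stronger inhibition and higher numbers for weaker inhibition), compound 1 (`Nc1ncnc2c1c(-c1ccc(NC(=O)c3ccccc3)cc1)cn2[C@H]1CCN(C[C@@H]2CO2)C1`) gives 5390 nM. For the measured compounds named here, compound 2 (`CC(C)(C)c1ccc(COc2ccc(-c3cn([C@H]4CCN(C[C@@H]5CO5)C4)c4ncnc(N)c34)cc2)cc1`) gives 5970 nM, so the two numbers so far lie within the scatter of each other and compound 1 cannot be ranked against it. The next analogue is compound 3 (`CC(C)(C)c1ccc(C(=O)Nc2ccc(-c3cn([C@H]4CCN(C[C@@H]5CO5)C4)c4ncnc(N)c34)cc2)cc1`), which keeps the benzamido link of compound 1. The change is tert-butyl in place of hydrogen on an aromatic carbon of a six-membered aromatic ring of carbon only, para to a large group: tert-butyl in place of hydrogen on an aromatic carbon. In other words, phenyl becomes 4-(tert-butyl)phenyl.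

Going by the values given here, only one measured step bears on this. Placing (4-(tert-butyl)benzyl)oxy where benzamido stood gives a 1.1-fold higher number from compound 1 to compound 2 (0.04 log units; within the scatter), which is within the scatter. That step also replaces the amide, so no measurement isolates the tert-butyl group on the benzamido ring. With a tert-butyl-bearing compound 2 at 5970 nM, no shift beyond the scatter is expected in this assay. The expected step is a 1.1-fold lower number from compound 1 to compound 3 (0.03 log units; within the scatter). For compound 3 the estimated value is 5000 nM, with an expected range of 2000 nM to 12000 nM.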

Compound 3, half-maximal inhibitory concentration: 3290 nM
Estimate against measurement, compound 3: 1.5-fold (0.18 log units) above; the range from low to high includes it.
By their numbers in this assay, from the lowest: compounds 3, 1 and 2 (each within the scatter of the next).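

In this assay, the change to compound 3 isolates tert-butyl in place of hydrogen on an aromatic carbon, para to a large group, with the benzamido link left intact, and the step reads a 1.6-fold lower number from compound 1 to compound 3 (0.21 log units; within the scatter). For the compounds shown here, the earlier comparison replaced the amide link along with the rest of the substituent, so this is the first reading of the group on its own: at this position, phenyl and 4-(tert-butyl)phenyl cannot be told apart in this read-out, even with the added carbons of the tert-butyl group. No measurement at hand offers an explanation for this reading.

From the compounds shown here alone, what an amine or a carboxylic acid would do in place of the tert-butyl group remains open, as does whether any group at this position can move the number beyond the scatter. The part played by the amide link also stays open, since compound 1 and compound 3 both carry the amide hydrogen, and an analogue with a methyl group on that nitrogen is not among the compounds shown.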